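Shortening the alkyl chain on a deoxyuridine core

The source may hold more compounds than are shown below. What is called first, only, known or untested is meant among the compounds shown, and "the series" means these compounds.

Compound 1 `CCCCCCCCc1cn([C@H]2C[C@H](O)[C@@H](CO)O2)c(=O)[nH]c1=O` carries an octyl chain on its core. In a functional assay on Raji cells (Homo sapiens) (a higher number here means a weaker inhibitor, a lower number a stronger inhibitor), compound 1 gives 52 ug/mL, the only numerical result among the two compounds measured, so no second number exists to rank it against. Compound 2 `CCCCCc1cn([C@H]2C[C@@H]3OP(=O)(O)OC[C@H]3O2)c(=O)[nH]c1=O` bears a pentyl chain and differs at the sugar, where a phosphate closes a further ring. For compound 2 this assay reports only a limit, > 500 ug/mL, not a number. That limit is the single outcome recorded for it (the limit of > 500 ug/mL in this assay, at which 1 of the 2 values shown sits). Compound 3 `CCCCCc1cn([C@H]2C[C@H](O)[C@@H](CO)O2)c(=O)[nH]c1=O` keeps the open sugar of compound 1 together with the pentyl chain of compound 2, and has not yet been tested. Its difference from compound 1 is hydrogen in place of propyl on a saturated chain carbon, five bonds along the chain from an aromatic carbon. Among the compounds with values here, no step between two measured compounds is available, so the size of this step can only be estimated. The step from compound 1 to compound 3 is expected to be a 2.9-fold higher number from compound 1 to compound 3 (0.46 log units; beyond the scatter), toward weaker inhibition, beyond the scatter yet short of the limit. Compound 3 is therefore expected to give 150 ug/mL in this assay, within a range from 50 ug/mL to 500 ug/mL.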

Compound 3, concentration for 50% inhibition: 334 ug/mL
Beside the measured number, compound 3's estimate is 2.2-fold (0.35 log units) below it, within the range that was stated.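

Within the data shown here, replacing propyl with hydrogen on a saturated chain carbon, five bonds along the chain from an aromatic carbon, turns the octyl chain into a pentyl chain and gives the first measured step at this position: a 6.4-fold higher number from compound 1 to compound 3 (0.81 log units; beyond the scatter) in this assay. With the sugar unchanged, this shows that chain length alone moves the read-out beyond the scatter, and that the shorter chain goes with weaker inhibition in this one pair, while the pentyl compound still gives a number rather than a limit. Compound 2 has the same pentyl chain as compound 3 and differs only at the sugar, where a phosphate closes a further ring, and its result is a limit, not a number: the limit of > 500 ug/mL in this assay, at which 1 of the 3 values shown sits.

Among these compounds, with only two chain lengths measured on the open sugar, it remains unknown whether the number changes smoothly across a hexyl or heptyl chain, or whether a longer chain such as decyl would give a lower number still. On these data alone, it is also open how a chain ending in an amine or a carboxylic acid would behave here, and whether an octyl chain would give a number on the sugar of compound 2.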